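This account rests on a few compounds, and the source may have more. Where it says the series, first, only, none or still open, it means among the compounds named here.

The measured compounds:
Compound 1, `O=C(O)Cc1sc(C(c2ccc(F)cc2)c2ccc(F)cc2)nc1-c1ccnc(N2CCC2)c1`, gives in an in vitro functional assay on HEK285-7 cells for antagonist activity at prostaglandin D2 receptor 2 (Homo sapiens), read by BRET and beta-arrestin recruitment (on this read-out higher numbers stand for weaker inhibition and lower numbers for stronger inhibition), only the limit > 100000 nM.
Compound 2, `COc1ccc(OC)c(-c2nc(C(c3ccccc3)c3ccccc3)sc2CC(=O)O)c1`, gives in this assay only the limit > 100000 nM.
Compound 3, `O=C(O)Cc1sc(C(c2ccccc2)c2ccc(Cl)cc2)nc1-c1ccc(Cl)cc1`, gives in this assay the value 75 nM.

Compound 1 stands at the limit of > 100000 nM in this assay, at which 2 of the 3 values shown sit, so for it there is a limit and no number. Among the compounds with values here, compound 2 also sits at a limit, whereas compound 3 gives a number; these three compounds differ from one another in more than one place, so their values can only be set side by side and no measured step connects them.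

Compound 4, `O=C(O)Cc1sc(C(c2ccc(F)cc2)c2ccc(F)cc2)nc1-c1ccnc(Cl)c1`, has yet to be measured in this assay. It differs from compound 1 by chloro in place of azetidin-1-yl on an aromatic carbon. Within the data shown here, with no measured step to lean on, the expected size of the change rests only on the limit of compound 1 and the number of compound 3. The step of an at least 5.0-fold lower number from compound 1 to compound 4 (0.69 log units; beyond the scatter) is expected to run toward stronger inhibition and to be sizeable, though it may still end at a limit. Compound 4 is estimated at 20000 nM, in a range from 1000 nM to 100000 nM.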

Compound 4, half-maximal inhibitory concentration: 39 nM
Compound 4: the middle estimate sits 510-fold (2.71 log units) above what was measured; the whole stated range lies above it.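

Within the data shown here, until now no measured step connected any of the compounds, so no single change could be tied to the read-out; this pair supplies the first one, on the aromatic carbon next to the ring nitrogen. In this assay compound 1 gives > 100000 nM, which is a limit and not a number, so the size of the step is itself only a bound: the change from 2-(azetidin-1-yl)pyridin-4-yl to 2-chloropyridin-4-yl gives an at least 2500-fold lower number from compound 1 to compound 4 (3.40 log units; beyond the scatter). This single place can therefore decide whether a compound stays at the limit or yields a number, and the bound rests on a limit shared with another compound: the limit of > 100000 nM in this assay, at which 2 of the 4 values shown sit.

The compounds shown leave open how hydrogen, methyl, methoxy or dimethylamino would read at this position. With a single pair, they also cannot tell whether other amines would behave like azetidin-1-yl.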